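The source may report more compounds than this note shows. Statements on the series, on what has been measured and on what is new or still open speak of the compounds shown alone.

Measured so far:
- Compound 1 `CCCCc1nc(=O)c(S(=O)(=O)c2ccc(-n3ccccc3=O)cc2)c(O)n1-c1c(OC)cccc1OC` — 83%
- Compound 2 `CCCCc1[nH]c(=O)c(S(=O)(=O)c2ccc(-c3ccc(F)cc3)cc2)c(O)c1-c1c(OC)cccc1OC` — "not determined" (no result reported)

In an ADME assay on microsomes from liver (Rattus norvegicus) for metabolic stability, using NADPH, with a stated time of 10 min (a lower number here means that less of the compound is left, a higher number that more of the compound is left), compound 1 gives 83%. For compound 2 no number is available in this assay, so compound 2 stands nowhere on the figures at hand; only its structure is known.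

Compound 3 `CCCCc1[nH]c(=O)c(S(=O)(=O)c2ccc(-n3ccccc3=O)cc2)c(O)c1-c1c(OC)cccc1OC` is the next member. It differs from compound 2 by a group of 7 heavy atoms (5 carbon, 1 nitrogen, 1 oxygen; one six-membered aromatic ring with 1 hetero atom) in place of a group of 7 heavy atoms (6 carbon, 1 fluorine; one six-membered aromatic ring of carbon only), on an aromatic carbon. The entering group is the same one that compound 1 carries on the same aromatic carbon, while compounds 1 and 3 differ in their core.

Going by the values given here, no step between measured compounds exists in this assay, so there is nothing to scale the change from compound 2 to compound 3 against. The expectation rests on compound 1 alone: because compound 1 gives 83% with the same terminal group, compound 3 is expected to remain largely intact in this assay, with the unmeasured core change leaving room for a shift in either direction beyond the scatter.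

Compound 3 is estimated at 75%, within a range of 52% to 95%.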

Compound 3, percent of the compound remaining: 100%
Compound 3: middle estimate off by 25 percentage points, on the low side; measured number above the stated range.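

No step can be read between compound 2 and compound 3 in this assay, as compound 2 has no number there. The compounds shown leave open how the 4-fluorophenyl group and the group replacing it compare on the shared core. No supporting data bear on the result for compound 3.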